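The source may report more compounds than this note shows. Statements on the series, on what has been measured and on what is new or still open speak of the compounds shown alone.

Measured compounds:
- Compound 1, `CC(C)=CCC/C(C)=C/COc1cc(=O)n(CCCO)c2c1CC(CC=C(C)C)C(C)(C)C2`: in a functional assay on PANC-1 cells (Homo sapiens) for inhibition, read by MTT assay, with a stated time of 24 h, tested at 10 uM (on this read-out lower numbers stand for less inhibition and higher numbers for more inhibition at the one concentration tested (going by the name of the read-out)), compound 1 gives 10.6%.
- Compound 2, `CC(C)=CCC1Cc2c(OCCCNS(=O)(=O)c3ccc(Br)cc3)cc(=O)n(CCCO)c2CC1(C)C`: compound 2 gives 19.5%.
- Compound 3, `CC(C)=CCC1Cc2c(OCCCNC(=O)c3ccco3)cc(=O)n(CCCO)c2CC1(C)C`: compound 3 gives 2.1%.

All three share the same core and differ only in the group at the end of the side chain attached through an oxygen on the aromatic ring. Compound 3 has the lowest of the three numbers. Its gap to compound 1 is within the scatter, so no order between those two can be claimed; its gap to compound 2 is beyond the scatter, a number 17.4 percentage points lower from compound 2 to compound 3 (beyond the scatter).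

Compound 4, `CC(C)=CCC1Cc2c(OCCCOc3ccc([N+](=O)[O-])cc3)cc(=O)n(CCCO)c2CC1(C)C`, is not yet measured. It differs from compound 3 in one place: 4-nitrophenoxy in place of ((furan-2-yl)carbonyl)amino on a saturated chain carbon, three bonds along the chain from an oxygen on an aromatic ring.

Going by the values given here, two measured steps touch this same chain end. Swapping in the furanoyl amide from the open dienyl chain gave a number 8.5 percentage points lower from compound 1 to compound 3 (within the scatter), and swapping it in for the sulfonamide gave a number 17.4 percentage points lower from compound 2 to compound 3 (beyond the scatter). Both replacements at this position moved the read-out only modestly, and both left compound 3 at the bottom. Reversing the direction, replacing the amide group with a nitrophenyl ether, is expected to move the number back up by a modest amount, a number 9.9 percentage points higher from compound 3 to compound 4 (within the scatter), while staying in the low range seen so far. Compound 4 is therefore expected to give about 12% in this assay, with a range from 0% to 28%.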

Compound 4, a percentage reported as inhibition, at one concentration (the size of the read-out at that concentration, not a potency): 47.5%
Estimate against measurement, compound 4: 35.5 percentage points below; measured number above the stated range.
By their numbers in this assay, from the lowest: compounds 3, 1 and 2 (each within the scatter of the next, the first and the last beyond it); then compound 4.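

In this assay, going by these compounds alone, this chain end can shift the read-out far more than the earlier compounds showed. Putting 4-nitrophenoxy at the end of the chain gives a number 45.4 percentage points higher from compound 3 to compound 4 (beyond the scatter) when it replaces the furan amide, a number 28 percentage points higher from compound 2 to compound 4 (beyond the scatter) when it replaces the sulfonamide, and a number 36.9 percentage points higher from compound 1 to compound 4 (beyond the scatter) when it replaces the open dienyl chain. Compound 4 therefore stands clear of all three others, and among these four compounds only the end joined through an oxygen on a benzene ring reaches this level.

Nothing measured here explains the rise. As far as these compounds go, it stays open whether the nitro group is needed: a plain phenoxy, or an amine in place of the nitro group on the same ring, would separate the ring from its substituent, and a longer chain would test the spacing.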